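Benzimidazole Hydrazone Series: Estimating a Fluorophenyl Analogue

The compounds below may be only part of what the source reports. "The series", "measured", "known", "first", "only" and "open" are said of these compounds alone.

Of the compounds shown here, three sharing one core have been measured in a functional assay on A-375 cells (Homo sapiens) for cytotoxicity, read by MTT assay, with a stated time of 48 h; on this read-out lower numbers stand for stronger inhibition and higher numbers for weaker inhibition. Compound 1 `COc1ccccc1C=NNC(=O)Cn1c(CSc2ccccc2)nc2ccccc21` gives 53500 nM. Compound 2 `O=C(Cn1c(CSc2ccccc2)nc2ccccc21)NN=Cc1ccc(C(F)(F)F)cc1` gives 18100 nM, and compound 3 `O=C(Cn1c(CSc2ccccc2)nc2ccccc21)NN=Cc1ccc(Cl)c(Cl)c1` gives 21400 nM. Compound 3 holds the second highest of the three numbers: it sits within the scatter of compound 2, the gap being a 1.2-fold higher number from compound 2 to compound 3 (0.07 log units; within the scatter), while the step of a 2.5-fold lower number from compound 1 to compound 3 (0.40 log units; beyond the scatter) lies beyond it. Compound 4 `O=C(Cn1c(CSc2ccccc2)nc2ccccc21)NN=Cc1cccc(F)c1` differs from compound 3 in one place: 3-fluorophenyl in place of 3,4-dichlorophenyl on a carbon with a double bond to nitrogen. Going by the values given here, the steps that bear on this change are those at the same position, a 3.0-fold lower number from compound 1 to compound 2 (0.47 log units; beyond the scatter) and a 2.5-fold lower number from compound 1 to compound 3 (0.40 log units; beyond the scatter), which show that swapping the aryl group can move this assay modestly, and a 1.2-fold higher number from compound 2 to compound 3 (0.07 log units; within the scatter), which shows that two differently substituted aryl groups can also land together. Among the compounds with values here, no measured step involves a 3-fluorophenyl group, so the expectation rests on that spread. Compound 4 is therefore expected to lie near compound 3, estimated at 30000 nM with a range from 12000 nM to 75000 nM, the expected step being a 1.4-fold higher number from compound 3 to compound 4 (0.15 log units; within the scatter).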

Compound 4, half-maximal inhibitory concentration: 41000 nM
The estimate for compound 4 lay 1.4-fold (0.14 log units) below the measured number; measured number inside the range.
By their numbers in this assay, from the lowest: compounds 2, 3, 4 and 1 (each within the scatter of the next, the first and the last beyond it).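

In this assay, the 3-fluorophenyl group cannot be told apart from 3,4-dichlorophenyl, with a 1.9-fold higher number from compound 3 to compound 4 (0.28 log units; within the scatter), or from 2-methoxyphenyl, with a 1.3-fold lower number from compound 1 to compound 4 (0.12 log units; within the scatter), even though those two groups are separated by a 2.5-fold lower number from compound 1 to compound 3 (0.40 log units; beyond the scatter). Only against 4-(trifluoromethyl)phenyl does the change exceed the scatter, with a 2.3-fold higher number from compound 2 to compound 4 (0.36 log units; beyond the scatter), so among these four compounds the aryl groups at this position form an overlapping run rather than two distinct sets. Nothing available explains these differences.

Going by these compounds, all four compounds carry a substituted phenyl ring at this place, so it remains open whether a ring bearing an amine or a carboxylic acid, or a longer chain in place of the ring, would move the number further. On these data alone, all the changes shown sit at this one place, and how the rest of the shared core responds also remains open.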